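Swapping the triazole arm of compound 1 for a hydroxypiperidine chain

The source may report more compounds than this note shows. Statements on the series, on what has been measured and on what is new or still open speak of the compounds shown alone.

Measured compounds:
compound 1 `O=C1c2c[n+]([O-])c3ccccc3c2C(=O)c2c1c1ccccc1n2Cc1cn(C[C@H](O)CO)nn1` gives 350 nM
compound 2 `O=C1c2c[n+]([O-])c3ccccc3c2C(=O)c2c1c1ccccc1n2CCN1CCCC1` gives 430 nM
compound 3 `CC1(C)O[C@@H](CO)[C@H](Cn2cc(Cn3c4c(c5ccccc53)C(=O)c3c[n+]([O-])c5ccccc5c3C4=O)nn2)O1` gives 190 nM

All three were tested in a functional assay on A-375 cells (Homo sapiens) for cytotoxicity, read by MTT assay, with a stated time of 72 h; a higher number here means a weaker inhibitor, a lower number a stronger inhibitor. Compound 1 sits second highest of the three numbers; its nearest neighbour is compound 2, a step of a 1.2-fold higher number from compound 1 to compound 2 (0.09 log units; within the scatter), and its furthest is compound 3, a step of a 1.8-fold lower number from compound 1 to compound 3 (0.27 log units; within the scatter). Both steps lie within the usual scatter, so the three compounds cannot be told apart on these numbers.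

Compound 4 `O=C1c2c[n+]([O-])c3ccccc3c2C(=O)c2c1c1ccccc1n2CCCN1CCC(O)CC1` has not yet been measured. It differs from compound 1 in one place: 2-(4-hydroxypiperidin-1-yl)ethyl in place of 1-(2,3-dihydroxypropyl)-1H-1,2,3-triazol-4-yl on a saturated chain carbon bound to an aromatic nitrogen.

The step from compound 1 to compound 2 bears most directly on this change, since there too the whole 1-(2,3-dihydroxypropyl)-1H-1,2,3-triazol-4-yl group was exchanged for a saturated nitrogen ring on the same chain carbon, and that step stayed within the scatter. Compound 3 shows only that altering the diol end of the triazole arm also left the number within the scatter. On this basis no step beyond the scatter is expected for compound 4, with the estimated step being a 1.1-fold higher number from compound 1 to compound 4 (0.06 log units; within the scatter). Compound 4 is therefore expected to give about 400 nM, within a range from 200 nM to 800 nM.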

Compound 4, half-maximal inhibitory concentration: 240 nM
The estimate for compound 4 lay 1.7-fold (0.22 log units) above the measured number; measured number inside the range.
By their numbers in this assay, from the lowest: compounds 3, 4, 1 and 2 (each within the scatter of the next, the first and the last beyond it).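

In this assay, the whole 1-(2,3-dihydroxypropyl)-1H-1,2,3-triazol-4-yl group gives way to 2-(4-hydroxypiperidin-1-yl)ethyl with a 1.5-fold lower number from compound 1 to compound 4 (0.16 log units; within the scatter), so a second saturated nitrogen ring, this one six-membered and carrying a hydroxyl, is also accepted at this position. Exchanging pyrrolidin-1-yl for (4-hydroxypiperidin-1-yl)methyl gives a 1.8-fold lower number from compound 2 to compound 4 (0.25 log units; within the scatter), which shows that the ring size, the hydroxyl and the chain length can change together without leaving the scatter, though it cannot separate the three. Nothing available explains why such different arms give such similar numbers.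

An unsubstituted piperidine on the same chain would show whether the hydroxyl of compound 4 contributes at all. A carboxylic acid at the end of the arm would test whether this position accepts a group of a quite different kind.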